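Adding a Chlorobenzyl Group to a Weakly Active Scaffold

The compounds below may be only part of what the source reports. "The series", "measured", "known", "first", "only" and "open" are said of these compounds alone.

Measured so far:
compound 1 `O=C1C=CC2(C=C1)OCC(Cc1cc(C(F)(F)F)cc(C(F)(F)F)c1)C(=O)N2c1ccccc1`: 18500 nM
compound 2 `CC1COC2(C=CC(=O)C=C2)N(C(C)C)C1=O`: > 20000 nM

Both were tested in an assay on isolated protein for inhibition of N-lysine methyltransferase SMYD2 (Homo sapiens), read by filter binding, with a stated time of 1 h; a higher number here means a weaker inhibitor, a lower number a stronger inhibitor. Compound 1 gives a genuine number, though a weak one. For compound 2 the result is a limit of the assay, not a number. Compound 2 thus stands at the limit of > 20000 nM in this assay, at which 1 of the 2 values shown sits, so only the weak end of its activity is known, and any comparison to compound 1 rests on that limit alone.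

Compound 3 `CC(C)N1C(=O)C(Cc2ccc(Cl)cc2)COC12C=CC(=O)C=C2` is the next candidate. It differs from compound 2 by 4-chlorophenyl in place of hydrogen on a saturated chain carbon bound to a saturated ring carbon; the same difference, cut one bond further out, reads methyl to 4-chlorobenzyl. Compound 1 also carries a substituted benzyl group and reaches a measurable value, so a benzyl-type arm is compatible with some inhibition. The step from compound 2 to compound 3 is expected to be small and toward stronger inhibition, or none beyond the scatter, since compound 2 is known only as a limit. Compound 3 is estimated at 12000 nM, within 3000 nM to 40000 nM, an expected step of an at least 1.6-fold lower number from compound 2 to compound 3 (0.22 log units; that floor lies within the scatter).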

Compound 3, half-maximal inhibitory concentration: > 20000 nM
Compound 3: a limit, no number; the forecaster's own chance of this, stated with the estimate: 40%; middle value at least 1.6-fold (0.22 log units) away from the limit.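

Compound 2 and compound 3 both end at a limit of the assay rather than a number, so no step can be read between them: the limit of > 20000 nM in this assay, at which 2 of the 3 values shown sit.

The compounds shown leave open whether 4-chlorophenyl in place of hydrogen on a saturated chain carbon bound to a saturated ring carbon changes inhibition at all.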